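Ring Size on the Amide Nitrogen: Cyclohexyl to Cyclooctyl

A few compounds are considered here, and "the series" means these few. Any claim that something is new, unique, unknown or untested is made for them only; others in the source may bear on it.

Measured compounds:
compound 1 `O=C(CCCCCCn1cc(C(=O)NCc2ccc(Cl)cc2)c2ccccc21)NO` — 1.56 nM
compound 2 `O=C(CCCCCCn1cc(C(=O)NC2CCCCC2)c2ccccc21)NO` — 2.32 nM

Both compounds were tested in an assay on isolated protein for inhibition of protein deacetylase HDAC6 (Homo sapiens), read by fluorescence, with a stated time of 60 min; on this read-out lower numbers stand for stronger inhibition and higher numbers for weaker inhibition. Compound 2 carries a cyclohexyl group on an amide-type nitrogen, and in this assay compound 2 gives 2.32 nM, the higher of the two numbers measured, with compound 1 as its nearest neighbour at 1.56 nM. Among the measured compounds shown here, the single measured step, a 1.5-fold higher number from compound 1 to compound 2 (0.17 log units; within the scatter), lies within the scatter, so the two compounds cannot be ordered on these numbers.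

Compound 3 `O=C(CCCCCCn1cc(C(=O)NC2CCCCCCC2)c2ccccc21)NO` has not yet been measured. It differs from compound 2 in one place: cyclooctyl in place of cyclohexyl on an amide-type nitrogen. For the measured compounds named here, the only step that bears on this change is the one from compound 1 to compound 2, which swapped the group on the same amide-type nitrogen and moved the number by a 1.5-fold higher number from compound 1 to compound 2 (0.17 log units; within the scatter), within the scatter. On that basis no step beyond the scatter is expected for compound 3, and the estimated step is a 1.1-fold higher number from compound 2 to compound 3 (0.03 log units; within the scatter) in this assay. For compound 3 the expected value is 2.5 nM, with an estimated range from 1.2 nM to 5.5 nM.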

Compound 3, half-maximal inhibitory concentration: 1.8 nM
Compound 3: the middle estimate sits 1.4-fold (0.14 log units) above what was measured, and the stated range covers the measured number.
By their numbers in this assay, from the lowest: compounds 1, 3 and 2 (each within the scatter of the next).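

In this assay, going from a six-membered to an eight-membered carbon ring on the amide-type nitrogen gives a 1.3-fold lower number from compound 2 to compound 3 (0.11 log units; within the scatter) and so produces no readable change, which shows that this position accepts cyclooctyl as well as cyclohexyl, at least on these numbers. Among the compounds shown here, until now, only one swap at this nitrogen had been seen; the comparison with the 4-chlorobenzyl compound gives a 1.2-fold higher number from compound 1 to compound 3 (0.06 log units; within the scatter) and is just as flat. All three groups, one with an aromatic ring carrying chlorine and two with carbon-only rings of different sizes, therefore stand within the scatter of one another, and none can be ranked above another. No accompanying measurement is available that could account for this flat picture.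

The compounds shown leave open how far this flat picture extends: a much smaller ring such as cyclopropyl, a ring carrying an amine or a carboxylic acid, or a long open carbon chain on the same nitrogen might move the number beyond the scatter. They also leave open whether cyclooctyl would behave the same way on a changed core.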